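Aryl Guanidine Variation in a Rat Aorta Assay

A few compounds are considered here, and "the series" means these few. Any claim that something is new, unique, unknown or untested is made for them only; others in the source may bear on it.

Of the compounds shown here, three that share one core have been measured in a functional assay (aorta) with Rattus norvegicus as the target; on this read-out higher numbers stand for weaker inhibition and lower numbers for stronger inhibition. Compound 1 `C/N=C(\NC#N)N[C@@H]1c2cc(C#N)ccc2OC(C)(C)[C@H]1O` gives 200 nM in this assay. Compound 2 `COC(=O)c1cn([C@@H]2c3cc(C#N)ccc3OC(C)(C)[C@H]2O)c2ccccc12` gives 500 nM in this assay. Compound 3 `CC1(C)Oc2ccc(C#N)cc2[C@@H](/N=C(\NC#N)Nc2cccc(Cl)c2)[C@@H]1O` gives 600 nM in this assay, the highest of the three numbers. Its nearest neighbour is compound 2, whose number lies within the usual scatter of that of compound 3, so no order can be claimed between these two. Compound 1 stands furthest away, with a lower number that lies beyond the scatter, so compound 1 inhibits more strongly than compound 3.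

Compound 4 `Cc1ccc(N/C(=N/[C@@H]2c3cc(C#N)ccc3OC(C)(C)[C@H]2O)NC#N)cc1C` has not yet been measured. It differs from compound 3 in one place: 3,4-dimethylphenyl in place of 3-chlorophenyl on an amine nitrogen. Within the data shown here, no measured pair in this set shows what such a change does in this assay, so the expectation rests on compound 3 alone.

Because compound 3 gives 600 nM and the change keeps the same aromatic ring on the same amine nitrogen, the expected step in this assay is no change at the digits printed from compound 3 to compound 4 (within the scatter), that is, none beyond the scatter in either direction. Compound 4 is therefore estimated at 600 nM in this assay, with a range from 250 nM to 1500 nM.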

Compound 4, half-maximal inhibitory concentration: 5100 nM
For compound 4 the middle estimate is 8.5-fold (0.93 log units) below the measured one, outside the stated range (above it).
By their numbers in this assay, from the lowest: compound 1; then compounds 2 and 3 (each within the scatter of the next); then compound 4.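

In this assay, among these compounds, the aryl group on this amine nitrogen proves not to be freely interchangeable: 3,4-dimethylphenyl in place of 3-chlorophenyl gives an 8.5-fold higher number from compound 3 to compound 4 (0.93 log units; beyond the scatter), the first step in this set between compounds that differ in one place, and it lies beyond the scatter. The two groups each carry one six-membered aromatic ring of carbon only and have no hydrogen-bond donors or acceptors, so these counts do not separate them. No measurement shown here bears on the reason for this step.

The swap removes the chlorine and adds two methyl groups in a single change, so the compounds shown cannot say how much each part contributes, or whether the loss of chlorine or the presence of the methyl groups matters more. A plain phenyl, a phenyl with a single methyl group, or a pyridine ring on the same nitrogen would remain to be placed against compound 3 and compound 4.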